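Lengthening the chain and moving back to para substitution

This account rests on a few compounds, and the source may have more. Where it says the series, first, only, none or still open, it means among the compounds named here.

Compound 3 `O=S(=O)(NCCNc1nccc(-c2c(-c3cccc(F)c3)nc3sccn23)n1)c1cccc(F)c1` stands at the highest number of the three measured compounds: in a functional assay on SK-MEL-28 cells (Homo sapiens) for cytotoxicity, read by MTT assay (on this read-out lower numbers stand for stronger inhibition and higher numbers for weaker inhibition), compound 3 gives 18300 nM. Compound 1 `O=S(=O)(NCCNc1nccc(-c2c(-c3cccc(F)c3)nc3sccn23)n1)c1ccc(F)cc1` gives 9450 nM, and compound 2 `O=S(=O)(NCCCNc1nccc(-c2c(-c3cccc(F)c3)nc3sccn23)n1)c1ccc(Cl)cc1` gives 8450 nM. The change a 1.9-fold higher number from compound 1 to compound 3 (0.29 log units; within the scatter) lies within the scatter, while a 2.2-fold higher number from compound 2 to compound 3 (0.34 log units; beyond the scatter) is a modest step, and a 1.1-fold lower number from compound 1 to compound 2 (0.05 log units; within the scatter) is flat.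

Compound 4 `Cc1ccc(S(=O)(=O)NCCCNc2nccc(-c3c(-c4cccc(F)c4)nc4sccn34)n2)cc1` arises from compound 3 by the change ((((4-methylphenyl)sulfonyl)amino)methyl in place of ((3-fluorophenyl)sulfonyl)amino on a saturated chain carbon, two bonds along the chain from a nitrogen on an aromatic ring). Going by the values given here, two measured steps bear on it. Compound 4 shares with compound 2 the longer chain and a para substituent on the sulfonyl ring, and the step from compound 2 to compound 3 was a 2.2-fold higher number from compound 2 to compound 3 (0.34 log units; beyond the scatter). Running that step in reverse, a modestly lower number is therefore expected for compound 4, although with the para methyl in place of chlorine the size is uncertain. The expected step is a 2.2-fold lower number from compound 3 to compound 4 (0.33 log units; beyond the scatter) in this assay. Compound 4 is estimated at 8500 nM in this assay, with a range from 4000 nM to 18000 nM.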

Compound 4, half-maximal inhibitory concentration: 9500 nM
Beside the measured number, compound 4's estimate is 1.1-fold (0.05 log units) below it; the range from low to high includes it.
By their numbers in this assay, from the lowest: compounds 2, 1, 4 and 3 (each within the scatter of the next, the first and the last beyond it).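

In this assay, going by these compounds alone, methyl in place of chloro on an aromatic carbon gives no change that can be told apart, with a 1.1-fold higher number from compound 2 to compound 4 (0.05 log units; within the scatter) as the first direct reading of that swap. The two larger replacements also stay inside the scatter, with a 1.0-fold higher number from compound 1 to compound 4 (0.00 log units; within the scatter) and a 1.9-fold lower number from compound 3 to compound 4 (0.28 log units; within the scatter), so (((4-methylphenyl)sulfonyl)amino)methyl cannot be separated here from either ((4-fluorophenyl)sulfonyl)amino or ((3-fluorophenyl)sulfonyl)amino. No independent measurement is available to account for these results.

Still open, as far as these compounds go, is whether an amine or a carboxylic acid in place of methyl on that aromatic carbon would move the number beyond the scatter. From the compounds shown here alone, it is also open whether a longer chain on the saturated carbon would do so.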